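This account rests on a few compounds, and the source may have more. Where it says the series, first, only, none or still open, it means among the compounds named here.

Measured in an ADME assay on MRC5 cells (Homo sapiens), read by MTT assay, with a stated time of 72 h; a higher number here means a weaker inhibitor, a lower number a stronger inhibitor:
- compound 1 `Cc1nc(N)c2c(-c3ccco3)cn([C@@H]3O[C@H](CO)[C@@H](O)[C@H]3O)c2n1`: > 100000 nM
- compound 2 `Cc1nc(N)c2c(-c3ccoc3)cn([C@@H]3O[C@H](CO)[C@@H](O)[C@H]3O)c2n1`: > 100000 nM
- compound 3 `Cc1nc(N)c2c(-c3ccsc3)cn([C@@H]3O[C@H](CO)[C@@H](O)[C@H]3O)c2n1`: > 100000 nM

All three entries are limits, not numbers: the limit of > 100000 nM in this assay, at which 3 of the 3 values shown sit. Compound 3 therefore has only a limit, with no exact position in the series.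

Compound 4 `Cc1nc(N)c2c(-c3cc4ccccc4o3)cn([C@@H]3O[C@H](CO)[C@@H](O)[C@H]3O)c2n1` carries 1-benzofuran-2-yl in place of thiophen-3-yl on an aromatic carbon.

The closest evidence is the three exchanges of one aromatic group for another: a step that the two limits leave unreadable from compound 1 to compound 2, a step that the two limits leave unreadable from compound 1 to compound 3 and a step that the two limits leave unreadable from compound 2 to compound 3. None has a readable size. No step beyond the scatter is expected in this assay, although one six-membered aromatic ring of carbon only is new to the set.

The expected change is an at least 1.2-fold lower number from compound 3 to compound 4 (0.09 log units; that floor lies within the scatter). For compound 4 the estimated value is 80000 nM, with an expected range of 25000 nM to 100000 nM.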

Compound 4, half-maximal inhibitory concentration: 91800 nM
Compound 4: middle estimate off by 1.1-fold (0.06 log units), on the low side; the measured number falls inside the stated range.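

In this assay, among these compounds, compound 4 is the first compound at this position with a number rather than a limit, and its 1-benzofuran-2-yl group adds a six-membered aromatic ring of carbon only. The readable steps are an at least 1.0-fold lower number from compound 3 to compound 4 (0.03 log units; that floor lies within the scatter), an at least 1.0-fold lower number from compound 2 to compound 4 (0.03 log units; that floor lies within the scatter) and an at least 1.0-fold lower number from compound 1 to compound 4 (0.03 log units; that floor lies within the scatter), so this change establishes no shift beyond the scatter. The steps among the other compounds cannot be read, and the series still sits mostly at a limit: the limit of > 100000 nM in this assay, at which 3 of the 4 values shown sit.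

Going by these compounds, what a phenyl group, or a longer chain ending in an amine, would give at this position in this assay stays open.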